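The source may report more compounds than this note shows. Statements on the series, on what has been measured and on what is new or still open speak of the compounds shown alone.

Compound 2 `O=C(/C=C\c1ccc(O)cc1)N1N=C(c2ccncc2)OC1c1c[nH]c2ccccc12` stands, in an ADME assay on PANC-1 cells (Homo sapiens) for cytotoxicity, read by MTT assay, with a stated time of 48 h (a higher number here means a weaker inhibitor of growth, a lower number a stronger inhibitor of growth), only at a limit of the measurement: compound 2 gives > 30 ug/mL. Its parent, compound 1 `O=C(/C=C\c1ccccc1)N1N=C(c2ccncc2)OC1c1c[nH]c2ccccc12`, is in the same position. In this assay compound 1 gives > 30 ug/mL, which is likewise a limit and not a number. Within the data shown here, the step from the one to the other, a step that the two limits leave unreadable from compound 1 to compound 2, therefore cannot be sized, and the only evidence on the measured compounds is the limit of > 30 ug/mL in this assay, at which 2 of the 2 values shown sit.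

Compound 3 `O=C(/C=C\c1ccccc1[N+](=O)[O-])N1N=C(c2ccncc2)OC1c1c[nH]c2ccccc12` is the next member of the set. It differs from compound 2 by 2-nitrophenyl in place of 4-hydroxyphenyl on a double-bonded chain carbon bound to a double-bonded chain carbon. No measured step bears on this change, since the two values already shown are both limits. Among the measured compounds shown here, the expectation for a step that the limit leaves unreadable from compound 2 to compound 3 is therefore no step that can be read beyond the scatter, with a further limit the most likely outcome. In this assay compound 3 is expected to give about 40 ug/mL, with a range from 15 ug/mL to 100 ug/mL.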

Compound 3, concentration for 50% growth inhibition: > 30 ug/mL
Compound 3: only a limit was reported; the forecaster's own chance of this, stated with the estimate: 75%; the middle value lies beyond the limit too.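

No step can be read for compound 3, since its comparisons with compound 1 and compound 2 all rest on limits and not on numbers: the limit of > 30 ug/mL in this assay, at which 3 of the 3 values shown sit.

The compounds shown leave open whether the hydroxy and nitro changes make any difference in this assay.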